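Replacing a Piperidine Ring with a Carboxymethyl Amine

The source may hold more compounds than are shown below. What is called first, only, known or untested is meant among the compounds shown, and "the series" means these compounds.

Compound 1, `COc1cc(OC)c2c(=O)cc(-c3ccccc3Cl)oc2c1CN1CCCCC1`, gives 23700 nM in a functional assay on MCF7 cells (Homo sapiens) for antiproliferative activity, with a stated time of 72 h; a higher number here means a weaker inhibitor, a lower number a stronger inhibitor.
Compound 2, `COc1cc(OC)c(C(=O)/C=C/c2ccccc2Cl)c(O)c1CN(C)CCCN(C)C`, gives 3200 nM in this assay.
Compound 3, `COc1cc(OC)c(C(=O)/C=C/c2ccccc2Cl)c(O)c1CN1CCCCC1`, gives 2600 nM in this assay.

Compound 3 holds the lowest of the three numbers. Its gap to compound 2 lies within the scatter, so the two cannot be told apart, whereas the gap to compound 1 lies beyond the scatter. Compound 4, `COc1cc(OC)c(C(=O)/C=C/c2ccccc2Cl)c(O)c1CN(C)CC(=O)O`, has not yet been measured. It differs from compound 3 in one place: (carboxymethyl)(methyl)amino in place of piperidin-1-yl on a saturated chain carbon bound to an aromatic carbon.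

For the measured compounds named here, only one measured step touches the same position. There, a 1.2-fold lower number from compound 2 to compound 3 (0.09 log units; within the scatter), so swapping one amine for another on that saturated chain carbon left the number essentially unchanged. Going by the values given here, the entering group in compound 4, however, brings a carboxylic acid, and no measured pair shows what such a group does here. Among the compounds with values here, the single relevant step gives no reason to expect a large shift, but the acid is new ground, so the range must be wide. Compound 4 is expected to give roughly 5000 nM, between 1800 nM and 15000 nM, which would mean a 1.9-fold higher number from compound 3 to compound 4 (0.28 log units; within the scatter) as an estimated step.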

Compound 4, half-maximal inhibitory concentration: 73200 nM
Estimate against measurement, compound 4: 15-fold (1.17 log units) below, outside the stated range (above it).
By their numbers in this assay, from the lowest: compounds 3 and 2 (each within the scatter of the next); then compound 1; then compound 4.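

Swapping one amine for another on the saturated chain carbon bound to an aromatic carbon had left the number unchanged within the scatter, which made this position look forgiving, but compound 4 shows that it does not accept every group of this size. In this assay there is a 28-fold higher number from compound 3 to compound 4 (1.45 log units; beyond the scatter) when (carboxymethyl)(methyl)amino replaces piperidin-1-yl, even though the two groups have the same number of heavy atoms, and the comparison with the open-chain diamine tells the same story, with a 23-fold higher number from compound 2 to compound 4 (1.36 log units; beyond the scatter) when carboxy replaces 2-(dimethylamino)ethyl on a saturated chain carbon bound to an amine nitrogen. No measurement is available that explains this rise.

The compounds shown leave open whether the rise belongs to the free carboxylic acid itself or to any carbonyl group on this chain, a question that a methyl ester or a primary amide of the same chain could answer. A longer chain ending in a carboxylic acid would further show whether the distance of the acid from the amine nitrogen changes the number.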